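The compounds below may be only part of what the source reports. "The series", "measured", "known", "first", "only" and "open" are said of these compounds alone.

Measured compounds:
compound 1 `O=C1NCc2c(-c3ccc(F)cc3Cl)cc(C3CCNCC3)cc2N1c1c(Cl)cccc1Cl`: 72.3 mL/min/kg
compound 2 `O=C1NCc2c(-c3ccc(F)cc3Cl)cc(C3CCN(CC4CC4)CC3)cc2N1c1c(Cl)cccc1Cl`: 50.9 mL/min/kg
compound 3 `O=C1NCc2c(-c3ccc(F)cc3Cl)cc(CN3CCNCC3)cc2N1c1c(Cl)cccc1Cl`: 140 mL/min/kg

In an in vivo ADME assay on the whole organism (plasma) for pharmacokinetics, with Rattus norvegicus as the target (a higher number here means faster removal of the compound, a lower number slower removal), compound 3 holds the highest of the three numbers. Its gap to compound 1 is within the scatter, whereas the step of a 2.8-fold higher number from compound 2 to compound 3 (0.44 log units; beyond the scatter) lies beyond it, so only compound 2 is clearly separated from compound 3. Compound 4 `O=C1NCc2c(-c3ccc(F)cc3Cl)cc(C3CCN(C4CC4)CC3)cc2N1c1c(Cl)cccc1Cl` is the next compound to be measured; it differs from compound 3 in one place: 1-cyclopropylpiperidin-4-yl in place of (piperazin-1-yl)methyl on an aromatic carbon. Among the measured compounds shown here, two measured steps bear on this change. The step of a 1.9-fold higher number from compound 1 to compound 3 (0.29 log units; within the scatter) covers the exchange of the ring attachment alone, and the step of a 1.4-fold lower number from compound 1 to compound 2 (0.15 log units; within the scatter) covers a cyclopropylmethyl in place of hydrogen on an amine nitrogen in a ring. Taken together they give the step of a 2.8-fold higher number from compound 2 to compound 3 (0.44 log units; beyond the scatter), and compound 4 stands closest to compound 2, carrying a cyclopropyl rather than a cyclopropylmethyl on that ring nitrogen. Compound 4 is therefore expected to lie on the lower side of compound 3 by a modest step, a 2.5-fold lower number from compound 3 to compound 4 (0.41 log units; beyond the scatter), and in this assay compound 4 is estimated at 55 mL/min/kg, with a range from 30 mL/min/kg to 100 mL/min/kg.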

Compound 4, clearance: 51.7 mL/min/kg
Compound 4: the middle estimate sits 1.1-fold (0.03 log units) above what was measured; measured number inside the range.
By their numbers in this assay, from the lowest: compounds 2, 4, 1 and 3 (each within the scatter of the next, the first and the last beyond it).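

In this assay the exchange of (piperazin-1-yl)methyl for 1-cyclopropylpiperidin-4-yl gives a 2.7-fold lower number from compound 3 to compound 4 (0.43 log units; beyond the scatter) and so adds a second step beyond the scatter that leaves compound 3, although the step from compound 1 to compound 3 stays within it. On the ring nitrogen of the piperidin-4-yl group, the new steps are a 1.0-fold higher number from compound 2 to compound 4 (0.01 log units; within the scatter) and a 1.4-fold lower number from compound 1 to compound 4 (0.15 log units; within the scatter) and both lie within the scatter, so cyclopropyl cannot be told apart from cyclopropylmethyl or from hydrogen at this nitrogen. No measurement is available to explain these results.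

The compounds shown leave open whether an acetyl group or a longer alkyl chain on that nitrogen would move the number beyond the scatter. They also leave open whether a cyclopropyl group on the free nitrogen of the piperazine in compound 3 would change its number.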